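Capping a Phenolic Hydroxyl in a Lipophilic Chromone Series

This account rests on a few compounds, and the source may have more. Where it says the series, first, only, none or still open, it means among the compounds named here.

Compound 2, with the structure `CC/C=C\C/C=C\C/C=C\CCCCCCCc1cc(=O)c2c(O)c(C)c(O)c(C)c2o1`, is a chromone bearing a long unsaturated chain and two free hydroxyl groups. In a functional assay on MDA-MB-231 cells (Homo sapiens) for antiproliferative activity, read by MTT assay (on this read-out lower numbers stand for stronger inhibition and higher numbers for weaker inhibition), compound 2 gives 6790 nM, sitting level with compound 3 `CCCCC/C=C\C/C=C\CCCCCCCc1cc(=O)c2c(O)cc(O)cc2o1`, which gives 6790 nM. Compound 1 `CCCC/C=C\CCCCCCCCCc1cc(=O)c2c(O)cc(OCOC)c(C)c2o1`, which already carries a methoxymethoxy group, gives only the limit > 87000 nM rather than a number (the limit of > 87000 nM in this assay, at which 1 of the 3 values shown sits). The unmeasured compound 4 `CC/C=C\C/C=C\C/C=C\CCCCCCCc1cc(=O)c2c(O)c(C)c(OCOC)c(C)c2o1` differs from compound 2 by methoxymethyl in place of hydrogen on an oxygen on an aromatic ring. Going by the values given here, no measured pair isolates this change, so the expected step from compound 2 to compound 4 is taken as a clear weakening, a 4.4-fold higher number from compound 2 to compound 4 (0.65 log units; beyond the scatter), given that compound 1 reached only a limit. Compound 4 is therefore estimated at 30000 nM, in the range 8000 nM to 90000 nM.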

Compound 4, half-maximal inhibitory concentration: 16100 nM
The estimate for compound 4 lay 1.9-fold (0.27 log units) above the measured number; low and high end bracket the measured number.
By their numbers in this assay, from the lowest: compounds 2 and 3 (each within the scatter of the next); then compound 4. At a limit, above all of these: compound 1.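

Replacing hydroxy with methoxymethoxy while the rest of the molecule stays unchanged gives a 2.4-fold higher number from compound 2 to compound 4 (0.37 log units; beyond the scatter) in this assay. This is a modest weakening, and compound 4 still gives a measured number, so a free hydroxyl at this place is not required for activity on these cells. Compound 1 also carries a methoxymethoxy group but differs in other places too, and its > 87000 nM is a limit of the assay and not a number.

The compounds shown leave open whether an acetyl or ethyl group on this oxygen would give a smaller or larger step. They also leave open whether the same change gives a similar step on a different chain.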